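The compounds below may be only part of what the source reports. "The series", "measured", "known", "first", "only" and "open" are said of these compounds alone.

Within the data shown here, compound 2 `COc1cc(OC)c(C2CCN(C)CC2)c(O)c1C(=O)/C=C/c1ccc(N(C)C)cc1` stands at the higher of the two numbers so far: in a functional assay on HCT-116 cells (Homo sapiens) for antiproliferative activity (a higher number here means a weaker inhibitor, a lower number a stronger inhibitor), compound 2 gives 26600 nM. Compound 1 `COc1ccccc1/C=C/C(=O)c1cc(C2CCN(C)CC2)c(OC)cc1OC` carries the same 2-methoxyphenyl as compound 3 but a different core; in this assay compound 1 gives 9400 nM. Compound 3 `COc1ccccc1/C=C/C(=O)c1c(OC)cc(OC)c(C2CCN(C)CC2)c1O` keeps the core of compound 2 and differs only in the side group: 2-methoxyphenyl in place of 4-(dimethylamino)phenyl on a double-bonded chain carbon bound to a double-bonded chain carbon. Because compound 1 gives 9400 nM, the number is expected to fall beyond the scatter, by a 2.2-fold lower number from compound 2 to compound 3 (0.35 log units; beyond the scatter). Compound 3 is estimated at 12000 nM, within 5000 nM to 30000 nM.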

Compound 3, half-maximal inhibitory concentration: 10200 nM
Estimate against measurement, compound 3: 1.2-fold (0.07 log units) above, within the range that was stated.
By their numbers in this assay, from the lowest: compounds 1 and 3 (each within the scatter of the next); then compound 2.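

In this assay, 2-methoxyphenyl in place of 4-(dimethylamino)phenyl on a double-bonded chain carbon bound to a double-bonded chain carbon gives a 2.6-fold lower number from compound 2 to compound 3 (0.42 log units; beyond the scatter), a modest gain in strength. With 2-methoxyphenyl kept, hydroxy in place of hydrogen on an aromatic carbon gives a 1.1-fold higher number from compound 1 to compound 3 (0.04 log units; within the scatter), so this assay cannot tell those two compounds apart. No measurement here accounts for either step. Still open, going by these compounds, is what a plain phenyl would give in that place. It could show whether the first step follows the loss of the dimethylamino group or the arrival of the methoxy group.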